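Opening the terminal ring to a dimethylamino group

The source may report more compounds than this note shows. Statements on the series, on what has been measured and on what is new or still open speak of the compounds shown alone.

Compound 3 `C[C@@H](CCCN1CCCCC1)Nc1ccnc2cc(Cl)ccc12` carries a piperidin-1-yl group at the end of its side chain. In an assay for binding affinity, read by spectrophotometry (a higher number here means a weaker inhibitor, a lower number a stronger inhibitor), compound 3 gives 150000 nM. Its number lies close to those of its two neighbours: compound 1 `C[C@@H](CCCN1CCCC1)Nc1ccnc2cc(Cl)ccc12` gives 180000 nM and compound 2 `C[C@@H](CCCN1CCN(C)CC1)Nc1ccnc2cc(Cl)ccc12` gives 140000 nM, and the steps of a 1.3-fold lower number from compound 1 to compound 2 (0.11 log units; within the scatter), a 1.2-fold lower number from compound 1 to compound 3 (0.08 log units; within the scatter) and a 1.1-fold higher number from compound 2 to compound 3 (0.03 log units; within the scatter) all stay within the scatter. So far, swapping one saturated ring for another at the chain end has not moved the read-out.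

Compound 4 `C[C@@H](CCCN(C)C)Nc1ccnc2cc(Cl)ccc12` differs from compound 3 by dimethylamino in place of piperidin-1-yl on a saturated chain carbon, four bonds along the chain from a nitrogen on an aromatic ring. Going by the values given here, no measured step opens this ring, so the three steps among compound 1, compound 2 and compound 3 are the only guide, and each was within the scatter. On that basis the expected step of no change at the digits printed from compound 3 to compound 4 (within the scatter) is also within the scatter, with no direction beyond it. Compound 4 is therefore estimated at 150000 nM in this assay, with a range from 70000 nM to 320000 nM.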

Compound 4, half-maximal inhibitory concentration: 150000 nM
Beside the measured number, compound 4's estimate shows no gap at the digits printed; low and high end bracket the measured number.
By their numbers in this assay, from the lowest: compounds 2, 3, 4 and 1 (each within the scatter of the next).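

Compound 4, unlike the other three, has no ring at the chain end, so this change is more than a swap of one saturated ring for another, and this assay records no change at the digits printed from compound 3 to compound 4 (within the scatter) for it. The comparisons with the other two ring compounds read a 1.1-fold higher number from compound 2 to compound 4 (0.03 log units; within the scatter) and a 1.2-fold lower number from compound 1 to compound 4 (0.08 log units; within the scatter) so among these four compounds, on a saturated chain carbon four bonds along the chain from a nitrogen on an aromatic ring, having a ring there makes no difference that this read-out can detect. No measurement shown here accounts for this insensitivity.

Still open, going by these compounds, is whether any group at this chain end can move the number beyond the scatter, such as a carboxylic acid or a primary amine in place of dimethylamino. Also open, on these data alone, is what a longer chain carrying the same dimethylamino group would give.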